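A Sulfonamide Nitrogen Swap in Antiproliferative Analogues

The source may hold more compounds than are shown below. What is called first, only, known or untested is meant among the compounds shown, and "the series" means these compounds.

Of three compounds tested in a functional assay on HL-60 cells (Homo sapiens) for antiproliferative activity, read by sulforhodamine B assay, with a stated time of 72 h (on this read-out higher numbers stand for weaker inhibition and lower numbers for stronger inhibition), compound 3 `Cc1cc(NS(=O)(=O)c2ccc(Nc3nncc4ccccc34)cc2)no1` gives the highest number, 68 nM. Compound 1 `Clc1ccc(C(/C=C/c2ccccc2)=N\Nc2nncc3ccccc23)cc1` gives 7.4 nM, and compound 2 `O=C1CS/C(=N/Nc2nncc3ccccc23)N1c1ccccc1` gives 3 nM; both gaps to compound 3 lie beyond the scatter, so compound 3 is the weakest of the three. Among the compounds with values here, no pair among them differs in only one place, so no measured step is available. Compound 4 `O=S(=O)(Nc1ccccn1)c1ccc(Nc2nncc3ccccc23)cc1` differs from compound 3 in a single place: pyridin-2-yl in place of 5-methyl-1,2-oxazol-3-yl on a sulfonamide nitrogen. Within the data shown here, with no measured step of this kind to lean on, the step from compound 3 to compound 4 in this assay is expected to be small, a 1.1-fold lower number from compound 3 to compound 4 (0.05 log units; within the scatter), with no direction beyond the scatter. Compound 4 is thus expected to give about 60 nM, within 20 nM to 200 nM.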

Compound 4, half-maximal inhibitory concentration: 86 nM
The estimate for compound 4 lay 1.4-fold (0.16 log units) below the measured number; the measured number falls inside the stated range.
By their numbers in this assay, from the lowest: compound 2; then compound 1; then compounds 3 and 4 (each within the scatter of the next).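

Within the data shown here, the step at this position is a 1.3-fold higher number from compound 3 to compound 4 (0.10 log units; within the scatter) in this assay and gives the first measured comparison on the sulfonamide nitrogen. Here a six-membered aromatic ring with one hetero atom stands in place of a five-membered one with two, and the two numbers stay within the scatter of each other. Nothing available bears on why these two groups read alike. Still open, on these data alone, is whether a group without a hetero atom in its ring, such as phenyl, would read the same on this nitrogen. A small chain such as methyl, or a carboxylic acid on the ring, is equally untested in what is shown.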